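The source may hold more compounds than are shown below. What is called first, only, known or untested is meant among the compounds shown, and "the series" means these compounds.

Measured compounds:
- Compound 1, `CCCCc1cc(C(C)=O)c(O)cc1OCCCCC#N`: 13%
- Compound 2, `C=CCc1cc(C(C)=O)c(O)cc1OCC#N`: 2%

Of the compounds shown here, two have been measured in an assay on isolated protein for binding affinity to leukotriene B4 receptor 1 (Homo sapiens), tested at 1 uM; on this read-out higher numbers stand for more inhibition at the one concentration tested (going by the name of the read-out) and lower numbers for less inhibition. Compound 1, `CCCCc1cc(C(C)=O)c(O)cc1OCCCCC#N`, gives 13% in this assay. Compound 2, `C=CCc1cc(C(C)=O)c(O)cc1OCC#N`, gives 2% in this assay, the lower of the two numbers, and the gap to compound 1 lies beyond the usual scatter. Going by the values given here, the two compounds differ in more than one place, so no single step between them can be read off.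

Compound 3, `C=CCc1cc(C(C)=O)c(O)cc1OCCCCC#N`, has not yet been measured. It differs from compound 2 by 3-cyanopropyl in place of cyano on a saturated chain carbon bound to an oxygen on an aromatic ring. With this change compound 3 carries the same chain as compound 1 on that oxygen, while its other difference from compound 1 remains. The step of a number 8 percentage points higher from compound 2 to compound 3 (within the scatter) is expected to be a modest rise in this assay, of a size that may not clear the scatter. Compound 3 is therefore estimated at 10%, within a range from 0% to 22%.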

Compound 3, a percentage reported as inhibition, at one concentration (the size of the read-out at that concentration, not a potency): 57%
Compound 3: middle estimate off by 47 percentage points, on the low side, outside the stated range (above it).
By their numbers in this assay, from the lowest: compound 2; then compound 1; then compound 3.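

In this assay, 3-cyanopropyl in place of cyano on a saturated chain carbon bound to an oxygen on an aromatic ring gives a number 55 percentage points higher from compound 2 to compound 3 (beyond the scatter), which shows that with the rest of the molecule held fixed, this chain strongly affects the read-out. The second place matters as well: vinyl in place of propyl on a saturated chain carbon bound to an aromatic carbon gives a number 44 percentage points higher from compound 1 to compound 3 (beyond the scatter), a separate effect that the first two compounds, differing in more than one place, could not reveal. The data offer no explanation for either step.

Still open, as far as these compounds go, is how a longer chain on that oxygen, or an amine or a carboxylic acid in place of the nitrile, would read in this assay. Also open, from the compounds shown here alone, is whether each step would keep its size with the other place changed.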